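Where limits leave the next step unread

The source may hold more compounds than are shown below. What is called first, only, known or untested is meant among the compounds shown, and "the series" means these compounds.

Of the compounds shown here, three with a shared core have been tested in an ADME assay on SH-SY5Y cells (Homo sapiens) for cytotoxicity, read by MTT assay, with a stated time of 48 h (a lower number here means a stronger inhibitor, a higher number a weaker inhibitor), so far. Compound 1 `COc1ccc(C(=O)/C=C/c2ccc(C(=O)N3CCCC3)cc2)c(O)c1` gives > 100000 nM as a limit of the assay, not as a number. Compound 2 `CCCNC(=O)c1ccc(/C=C/C(=O)c2ccc(OC)cc2O)cc1` gives > 100000 nM as a limit too. Compound 3 `COc1ccc(C(=O)/C=C/c2ccc(C(=O)Nc3ccccc3OC)cc2)c(O)c1` gives > 100000 nM as a limit as well. Compound 3 therefore has no exact place on the scale, and the picture overall is the limit of > 100000 nM in this assay, at which 3 of the 3 values shown sit, with no number to rank the three.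

In compound 4 `COC(=O)c1ccc(/C=C/C(=O)c2ccc(OC)cc2O)cc1` methoxy takes the place of (2-methoxyphenyl)amino on a carbonyl carbon, a swap counted as methoxy in place of (2-methoxyphenyl)amino on a carbonyl carbon in full. The measured changes that bear on this are a step that the two limits leave unreadable from compound 1 to compound 2 together with a step that the two limits leave unreadable from compound 1 to compound 3 and a step that the two limits leave unreadable from compound 2 to compound 3 in this assay and none of them offers a size to carry over.

Resting on compound 3 at > 100000 nM as a limit, no step beyond the usual scatter is expected, in either direction, and another limit is the likeliest report. The expected change is a number no higher from compound 3 to compound 4 (the limit leaves the size open) by this estimate. For compound 4 the estimated value is 100000 nM with an expected range from 40000 nM to 200000 nM as the likely span.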

Compound 4, half-maximal inhibitory concentration: > 100000 nM
Compound 4 gave a limit, no number; the forecaster's own chance of this, stated with the estimate: 75%; the middle value lies on the limit itself.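

For the compounds shown here, compound 4, like compound 1, compound 2 and compound 3, gives only a limit in this assay, so no step between any of them can be read. All four sit at the same reported limit: the limit of > 100000 nM in this assay, at which 4 of the 4 values shown sit.

The compounds shown leave open whether the groups on the carbonyl carbon differ at all in this assay.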